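Bromo to methoxy exchange on compound 3

The source may report more compounds than this note shows. Statements on the series, on what has been measured and on what is new or still open speak of the compounds shown alone.

Values measured in a functional assay on K562 cells (Homo sapiens) for cytotoxicity, read by XTT assay, with a stated time of 24 h (a higher number here means a weaker inhibitor, a lower number a stronger inhibitor), as follows
- compound 1 `Cc1ccc(NC(=O)c2ccc(Br)cc2OCCCCn2ccnc2)cc1Nc1nccc(-c2cccnc2)n1` gives 66100 nM
- compound 2 `Cc1ccc(NC(=O)c2ccc([N+](=O)[O-])c(OCCCCn3ccnc3)c2)cc1Nc1nccc(-c2cccnc2)n1` gives 25000 nM
- compound 3 `Cc1ccc(NC(=O)c2ccc(OCCCCn3ccnc3)c(Br)c2)cc1Nc1nccc(-c2cccnc2)n1` gives 12000 nM

Compound 3 has the lowest number of the three and is the strongest of them, with compound 2 and compound 1 both higher by more than the scatter. The next compound is compound 4 `COc1cc(C(=O)Nc2ccc(C)c(Nc3nccc(-c4cccnc4)n3)c2)ccc1OCCCCn1ccnc1` and the change from compound 3 is methoxy in place of bromo on an aromatic carbon with methoxy in place of bromo on an aromatic carbon, ortho to a 4-(1H-imidazol-1-yl)butoxy group. Going by the values given here, no two measured compounds differ in one place, so the data hold no direct measure of this exchange. A small move toward a higher number is expected, possibly none beyond the scatter, since compound 3 at 12000 nM already stands lowest of the three. The expected change is a 1.3-fold higher number from compound 3 to compound 4 (0.12 log units; within the scatter) and it remains an estimate. For compound 4 the estimated value is 16000 nM with an expected range of 6000 nM to 42000 nM in this assay for now.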

Compound 4, half-maximal inhibitory concentration: 29500 nM
For compound 4 the middle estimate is 1.8-fold (0.27 log units) below the measured one; the range from low to high includes it.
By their numbers in this assay, from the lowest: compound 3; then compounds 2 and 4 (each within the scatter of the next); then compound 1.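

In this assay, going by these compounds alone, the exchange gives a 2.5-fold higher number from compound 3 to compound 4 (0.39 log units; beyond the scatter), the first direct reading of any single change. At this place on the aromatic ring, ortho to a 4-(1H-imidazol-1-yl)butoxy group, the number therefore responds to the group present, and for this one pair bromo gives the lower number and methoxy the higher. Nothing available bears on what lies behind this step.

From the compounds shown here alone, what a chloro, hydroxy or ethoxy group would give at this same place remains open, so the two groups tested do not yet define a trend. Going by these compounds, the exchange also rests on one pair, and whether the step would hold with a longer chain in place of the 4-(1H-imidazol-1-yl)butoxy group is unknown.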